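This account rests on a few compounds, and the source may have more. Where it says the series, first, only, none or still open, it means among the compounds named here.

Of the compounds shown here, three built on one shared core have been tested in a functional assay on the whole organism for inhibition, with Rattus norvegicus as the target, read by paw edema, with a stated time of 30 min, at a dose of 80 mg/kg by the oral route; a higher number here means a stronger effect of the compound at the dose given, a lower number a weaker effect. Compound 3 `O=[N+]([O-])c1ccc(OCC2=NCCO2)cc1` gives 77.1%. Compound 1 `Fc1ccc(OCC2=NCCO2)cc1` gives 40.5%; the change from compound 3 to compound 1 is fluoro in place of nitro on an aromatic carbon, and it made a step of a number 36.6 percentage points lower from compound 3 to compound 1 (beyond the scatter). Compound 2 `O=[N+]([O-])c1ccccc1OCC1=NCCO1` gives 50.5%; the difference between the core of compound 2 and that of compound 3 is not broken down here. Compound 4 `Fc1ccccc1OCC1=NCCO1` has not yet been measured. Its change from compound 2 is fluoro in place of nitro on an aromatic carbon, the same kind of change, though here the entering group sits ortho to a group of 7 heavy atoms rather than para to it. Because the same change gave a number 36.6 percentage points lower from compound 3 to compound 1 (beyond the scatter), a clear drop is expected, so that compound 4 is estimated at a step of a number 28.5 percentage points lower from compound 2 to compound 4 (beyond the scatter). Compound 4 is therefore expected to give about 22%, likely between 5% and 42%.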

Compound 4, a percentage reported as inhibition, in the whole organism at one dose (the size of the read-out at that dose, not a potency): 60.1%
Estimate against measurement, compound 4: 38.1 percentage points below, outside the stated range (above it).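

In this assay, putting fluoro in place of nitro gave a number 9.6 percentage points higher from compound 2 to compound 4 (within the scatter). This change therefore does not carry as one fixed step from one core to the other in this series, since the two steps differ by more than repeated measurements would explain: the same change on two cores in this assay, a number 36.6 percentage points lower (beyond the scatter) from compound 3 to compound 1 and a number 9.6 percentage points higher (within the scatter) from compound 2 to compound 4, 46.2 percentage points apart, beyond the scatter of two such steps The result shows that the outcome of the swap depends on the core that carries it, but two pairs cannot show why, or predict the step on any further core.

The compounds shown carry only fluoro or nitro on the aromatic ring. Going by these compounds, how an amine or a carboxylic acid in that place would read in this assay, and whether the two cores would then respond alike, stays open.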